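Swapping a Bromophenyl for a Chlorophenyl Group

A few compounds are considered here, and "the series" means these few. Any claim that something is new, unique, unknown or untested is made for them only; others in the source may bear on it.

In a functional assay on A549 cells (Homo sapiens) for inhibition, read by MTT assay, with a stated time of 24 h (a lower number here means a stronger inhibitor, a higher number a weaker inhibitor), compound 1 `CC1(C)[C@H]2CC[C@]1(C)N(Cc1cn(-c3ccccc3Br)nn1)C(=O)C2` gives 130 nM while compound 2 `CC1(C)[C@H]2CC[C@]1(C)N(Cc1cn(-c3cccc(Br)c3)nn1)C(=O)C2` gives 90 nM and the two values lie within the scatter of each other. Among the compounds with values here, compound 3 `CC1(C)[C@H]2CC[C@]1(C)N(Cc1cn(-c3ccc(Cl)cc3)nn1)C(=O)C2` has 4-chlorophenyl in place of 3-bromophenyl on an aromatic nitrogen and no measured compound yet carries chlorine. Within the data shown here, the only measured step is a 1.4-fold lower number from compound 1 to compound 2 (0.16 log units; within the scatter) and it exchanged one bromophenyl group for another. In this assay the expected change is therefore a 1.1-fold higher number from compound 2 to compound 3 (0.05 log units; within the scatter) and no shift beyond the scatter is anticipated in either direction. Compound 3 is estimated at 100 nM with an expected range from 40 nM to 250 nM in this measurement.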

Compound 3, half-maximal inhibitory concentration: 70 nM
The estimate for compound 3 lay 1.4-fold (0.15 log units) above the measured number; the range from low to high includes it.
By their numbers in this assay, from the lowest: compounds 3, 2 and 1 (each within the scatter of the next).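

In this assay, a chlorine-bearing group at this aromatic nitrogen gives a 1.3-fold lower number from compound 2 to compound 3 (0.11 log units; within the scatter) and a 1.9-fold lower number from compound 1 to compound 3 (0.27 log units; within the scatter). So 4-chlorophenyl stays within the scatter of both bromophenyl compounds, even though the halogen and its place on the phenyl ring change together. No measurement shown explains this result. The compounds shown leave open how 4-bromophenyl would compare, which would separate the halogen from its place on the ring. They also leave open whether a phenyl ring carrying an amine or a carboxylic acid would stay within this scatter.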